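Methyl for hydrogen on the saturated chain, at two placements

The source may hold more compounds than are shown below. What is called first, only, known or untested is meant among the compounds shown, and "the series" means these compounds.

Compound 1 `CCCc1ccc(/C=C/C(=O)Nc2ccc3nc(CCC)cc(N)c3c2)cc1` and compound 2 `CCCCc1ccc(/C=C/C(=O)Nc2ccc3nc(CCC)cc(N)c3c2)cc1` share one core; compound 3 `CC(C)c1cc(N)c2cc(NC(=O)/C=C/c3ccc(C(F)(F)F)cc3)ccc2n1` and compound 4 `CCC(C)c1cc(N)c2cc(NC(=O)/C=C/c3ccc(C(F)(F)F)cc3)ccc2n1` share another. The difference between the two cores is not broken down here.

In an assay on isolated protein for displacement of a labelled ligand from melanin-concentrating hormone receptor 1 (Homo sapiens) (a lower number here means a stronger inhibitor, a higher number a weaker inhibitor), compound 1 gives 4 nM. Compound 2 differs from it by methyl in place of hydrogen on a saturated chain carbon, three bonds along the chain from an aromatic carbon. The step is an 11-fold higher number from compound 1 to compound 2 (1.05 log units; beyond the scatter). Compound 2 accordingly gives 45 nM in this assay. Compound 3 gives 2.1 nM in this assay, a number that lies within the usual scatter of the number for compound 1.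

Compound 4 is the unmeasured member of the set: methyl in place of hydrogen on a saturated chain carbon, two bonds along the chain from an aromatic carbon. This is the same kind of change as that from compound 1 to compound 2, but not the same change. There the methyl enters three bonds along the chain from an aromatic carbon, cut one bond further out reading propyl to butyl; here it enters two bonds along the chain from an aromatic carbon, reading isopropyl to sec-butyl, and on a different core.

Among the compounds with values here, the only precedent for adding a methyl to this chain is the step of an 11-fold higher number from compound 1 to compound 2 (1.05 log units; beyond the scatter), a weakening beyond the scatter. Because of an 11-fold higher number from compound 1 to compound 2 (1.05 log units; beyond the scatter) a weakening is expected here too, though the placement one bond nearer the aromatic carbon and the change of core leave its size uncertain; the step from compound 3 to compound 4 is estimated at a 3.8-fold higher number from compound 3 to compound 4 (0.58 log units; beyond the scatter). Compound 4 is therefore expected to give about 8 nM in this assay, most likely between 2.5 nM and 40 nM.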

Compound 4, half-maximal inhibitory concentration: 0.3 nM
Compound 4: middle estimate off by 27-fold (1.43 log units), on the high side; measured number outside the range, below it.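

In this assay, methyl for hydrogen on a saturated chain carbon, two bonds along the chain from an aromatic carbon, gives a 7.0-fold lower number from compound 3 to compound 4 (0.85 log units; beyond the scatter), whereas the earlier methyl step, three bonds along the chain, gives an 11-fold higher number from compound 1 to compound 2 (1.05 log units; beyond the scatter). The weakening seen on the core of compound 1 therefore does not carry over to the core of compound 3; the direction reverses, and the two steps differ by more than their scatter: the same change on two cores in this assay, an 11-fold higher number (1.05 log units; beyond the scatter) from compound 1 to compound 2 and a 7.0-fold lower number (0.85 log units; beyond the scatter) from compound 3 to compound 4, 79-fold (1.90 log units) apart, beyond the scatter of two such steps The two steps differ in core, in placement and in which chain takes the methyl, so this comparison cannot assign the gap to any one of these, and a single pair on each core gives no rule for the series.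

Still open, as far as these compounds go, is how isopropyl to sec-butyl would read on the core of compound 1, and how a chain extended at the same place as in compound 2 would read on the core of compound 3, the two comparisons that would begin to separate core from placement. Also open, from the compounds shown here alone, is whether the stronger binding of compound 4 would persist with a longer chain such as pentyl, or with a tert-butyl group or a cyclopropyl ring in place of sec-butyl.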